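Swapping an Aromatic Ether for a Cyclic Amine

The source may hold more compounds than are shown below. What is called first, only, known or untested is meant among the compounds shown, and "the series" means these compounds.

Of the compounds shown here, three sharing one core have been tested so far in a functional assay for inhibition of sodium/hydrogen exchanger (Oryctolagus cuniculus); on this read-out higher numbers stand for weaker inhibition and lower numbers for stronger inhibition. Compound 1 `CCCCCc1cc(C)c(C(=O)N=C(N)N)cc1S(C)(=O)=O` gives 27 nM. Compound 2 `Cc1cc(-c2ccc(Cl)cc2)c(S(C)(=O)=O)cc1C(=O)N=C(N)N` gives 45 nM. Compound 3 `Cc1cc(Oc2ccccc2Cl)c(S(C)(=O)=O)cc1C(=O)N=C(N)N` gives 14 nM, the lowest number of the three: one step, a 1.9-fold lower number from compound 1 to compound 3 (0.29 log units; within the scatter), is within the scatter, while the other, a 3.2-fold lower number from compound 2 to compound 3 (0.51 log units; beyond the scatter), is beyond it.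

Compound 4 `Cc1cc(N2CCCC2)c(S(C)(=O)=O)cc1C(=O)N=C(N)N` carries the change (pyrrolidin-1-yl in place of 2-chlorophenoxy on an aromatic carbon). Among the measured compounds shown here, no measured step involves a cyclic amine at this position, so the bearing of the earlier steps is indirect. They show that three quite different groups at the same place on the core all land within a narrow band: a 1.7-fold higher number from compound 1 to compound 2 (0.22 log units; within the scatter) and a 1.9-fold lower number from compound 1 to compound 3 (0.29 log units; within the scatter) both lie within the scatter, and only a 3.2-fold lower number from compound 2 to compound 3 (0.51 log units; beyond the scatter) reaches beyond it. On that basis the change to compound 4 is expected to give a modest shift, if any, toward a higher number in this assay, with a step estimated at a 2.5-fold higher number from compound 3 to compound 4 (0.40 log units; beyond the scatter). Compound 4 is therefore expected to give about 35 nM, within a range from 10 nM to 120 nM.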

Compound 4, half-maximal inhibitory concentration: 11 nM
Compound 4: the middle estimate sits 3.2-fold (0.50 log units) above what was measured, within the range that was stated.
By their numbers in this assay, from the lowest: compounds 4, 3, 1 and 2 (each within the scatter of the next, the first and the last beyond it).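

In this assay, replacing 2-chlorophenoxy, with its 8 heavy atoms and six-membered aromatic ring, by pyrrolidin-1-yl, with 5 heavy atoms and a five-membered non-aromatic ring, gives a 1.3-fold lower number from compound 3 to compound 4 (0.10 log units; within the scatter). This shows that an aromatic ring in this group, ortho to the methylsulfonyl group, is not required for a number in this low range, and that a cyclic amine fits among the groups tolerated at this position. Compound 4 also stands apart from the two earlier compounds with a carbon directly on the ring, with a 4.1-fold lower number from compound 2 to compound 4 (0.61 log units; beyond the scatter) and a 2.5-fold lower number from compound 1 to compound 4 (0.39 log units; beyond the scatter), whereas the earlier 1.9-fold lower number from compound 1 to compound 3 (0.29 log units; within the scatter) did not separate compound 3 from the pentyl compound, and no measurement at hand explains any of these differences.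

The compounds shown leave open whether the ring of pyrrolidin-1-yl matters or only its nitrogen, which piperidin-1-yl, morpholin-4-yl or an open-chain dimethylamino group at the same position could help to settle. They also leave open what the chlorine of compound 3 contributes, a question that a plain phenoxy group would address.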